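Working notes on the step from compound 2 to compound 4

This account rests on a few compounds, and the source may have more. Where it says the series, first, only, none or still open, it means among the compounds named here.

Measured so far:
compound 1, `COc1ccc(-c2nc3cc(Cl)c(Cl)cc3[nH]2)cc1`: 30000 nM
compound 2, `Oc1ccc(-c2nc3cc(C(F)(F)F)ccc3[nH]2)cc1`: > 100000 nM
compound 3, `C#C[C@@]1(O)[C@H](O)[C@@H](CO)O[C@H]1n1ccc(N)nc1=O`: > 100000 nM

Three compounds have readings in an ADME assay on Vero cells (Chlorocebus sabaeus) for cytotoxicity; a higher number here means that more compound is tolerated, a lower number that less compound is tolerated. Compound 1 gives a number, 30000 nM. Compound 2 gives > 100000 nM, which is a limit of the assay and not a number. Compound 3 likewise returns a limit, > 100000 nM. Among the measured compounds shown here, compound 2 therefore stands at the limit of > 100000 nM in this assay, at which 2 of the 3 values shown sit; the reading of compound 1 is the only number among the three, and no step between measured compounds that differ in one place is available.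

Compound 4, `O=[N+]([O-])c1ccc(-c2nc3cc(C(F)(F)F)ccc3[nH]2)cc1`, has not yet been measured in this assay. It differs from compound 2 in one place: nitro in place of hydroxy on an aromatic carbon. No measured step shows the effect of nitro in place of hydroxy here, so no cause can be given. The expected step is an at least 1.4-fold lower number from compound 2 to compound 4 (0.15 log units; that floor lies within the scatter), either none beyond the scatter or a modest fall in the tolerated concentration. Compound 4 is expected to give about 70000 nM in this assay, within 20000 nM to 150000 nM, with a fair chance that only a limit is reported again.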

Compound 4, half-maximal cytotoxic concentration: 45000 nM
The estimate for compound 4 lay 1.6-fold (0.19 log units) above the measured number; low and high end bracket the measured number.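

In this assay, among the compounds shown here, nitro in place of hydroxy on an aromatic carbon gives an at least 2.2-fold lower number from compound 2 to compound 4 (0.34 log units; beyond the scatter), the first step that can be read. This position, para to a large group, is therefore not indifferent to the change, and compound 4 gives 45000 nM, a number that can serve as a reference point for further changes at this place. The size of the step is only a floor, because the value of compound 2 is a limit and not a number: the limit of > 100000 nM in this assay, at which 2 of the 4 values shown sit.

The compounds shown do not separate the departure of hydroxy from the arrival of nitro as the origin of the step. An amine or a carboxylic acid on the same aromatic carbon would show whether other groups at this place also lower the tolerated concentration.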